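This account rests on a few compounds, and the source may have more. Where it says the series, first, only, none or still open, it means among the compounds named here.

Measured compounds:
Compound 1 `COc1c(OCCCN2CCNCC2)cc(O)c2c(=O)cc(-c3ccccc3)oc12` gives 10100 nM.
Compound 2 `CN(C)CCCCOc1c(O)cc(O)c2c(=O)cc(-c3ccccc3)oc12` gives > 100000 nM.
Compound 3 `COc1c(OCCCCN2CCCC2)cc(O)c2c(=O)cc(-c3ccccc3)oc12` gives 1530 nM.

In a functional assay on A549 cells (Homo sapiens) for cytotoxicity, read by MTT assay, with a stated time of 48 h (a lower number here means a stronger inhibitor, a higher number a weaker inhibitor), compound 2 reaches only > 100000 nM, which is a limit of the assay and not a number. Among the three values shown, compound 2 therefore stands at the weak end, at the limit of > 100000 nM in this assay, at which 1 of the 3 values shown sits. Compound 4 `CN1CCN(CCCOc2c(O)cc(O)c3c(=O)cc(-c4ccccc4)oc23)CC1` differs from compound 2 by 4-methylpiperazin-1-yl in place of (dimethylamino)methyl on a saturated chain carbon, three bonds along the chain from an oxygen on an aromatic ring. For the measured compounds named here, no measured step changes exactly these two groups. Going by the values given here, the only measured step, a 6.6-fold lower number from compound 1 to compound 3 (0.82 log units; beyond the scatter), involves other groups on a different shared core, and it is modest. Compound 4 is therefore expected to remain weak in this assay, and compound 4 is estimated at 80000 nM, with a range from 20000 nM to 300000 nM. The expected step is an at least 1.2-fold lower number from compound 2 to compound 4 (0.09 log units; that floor lies within the scatter), which may well again end in a limit.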

Compound 4, half-maximal inhibitory concentration: > 100000 nM
Compound 4: only a limit was reported (the forecaster's own chance of this, stated with the estimate: 50%); middle value at least 1.2-fold (0.09 log units) from the limit.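

Compound 2 and compound 4 both end at a limit of the assay, and the step between them cannot be read. The compounds shown leave open whether 4-methylpiperazin-1-yl in place of (dimethylamino)methyl changes the result in this assay at all.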